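A few compounds are considered here, and "the series" means these few. Any claim that something is new, unique, unknown or untested is made for them only; others in the source may bear on it.

Compound 1, `Cc1ccc(NC(=O)NC2CCN(c3ncnc4[nH]ncc34)CC2)cc1`, gives 4710 nM in an assay on isolated protein for inhibition of serine/threonine-protein kinase PAK 1 (Homo sapiens), read by ADP-Glo, with a stated time of 40 min; on this read-out higher numbers stand for weaker inhibition and lower numbers for stronger inhibition.
Compound 2, `O=C(Nc1ccc(Br)cc1)NC1CCN(c2ncnc3[nH]ncc23)CC1`, gives 4030 nM in this assay.

Compound 2 carries the lower of the two numbers recorded so far, yet the step from compound 1 to compound 2, a 1.2-fold lower number from compound 1 to compound 2 (0.07 log units; within the scatter), lies within the scatter of repeated measurements, so the two compounds cannot be ranked against each other on this evidence.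

Compound 3, `O=C(Nc1ccc(C(F)(F)F)cc1)NC1CCN(c2ncnc3[nH]ncc23)CC1`, has not been measured. It differs from compound 2 by trifluoromethyl in place of bromo on an aromatic carbon, the exchange taking place on an aromatic carbon of a six-membered aromatic ring of carbon only. Going by the values given here, only one measured step bears on this change: the earlier exchange of one group at that same aromatic carbon, from compound 1 to compound 2, which gave a 1.2-fold lower number from compound 1 to compound 2 (0.07 log units; within the scatter). Among the compounds with values here, with a single step of that size as the only guide, the expected step in this assay is a 1.0-fold lower number from compound 2 to compound 3 (0.00 log units; within the scatter), no shift beyond the scatter in either direction. Compound 3 is therefore estimated at 4000 nM, with a range from 1500 nM to 11000 nM.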

Compound 3, half-maximal inhibitory concentration: 7150 nM
For compound 3 the middle estimate is 1.8-fold (0.25 log units) below the measured one, and the stated range covers the measured number.
By their numbers in this assay, from the lowest: compounds 2, 1 and 3 (each within the scatter of the next).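

In this assay, trifluoromethyl, with its 4 heavy atoms in place of the single heavy atom of bromo, gives a 1.8-fold higher number from compound 2 to compound 3 (0.25 log units; within the scatter) and, set against methyl at the same aromatic carbon, gives a 1.5-fold higher number from compound 1 to compound 3 (0.18 log units; within the scatter) as well. Going by these compounds alone, the earlier compounds offered only one exchange at this carbon, para to a large group, whereas three groups can now be compared there, and every step among methyl, bromo and trifluoromethyl stays within the scatter, so these three groups cannot be ranked against one another and the added heavy atoms bring no readable change in the number. No measurement accompanies these values that could account for them.

The compounds leave open whether a group of a different kind on this aromatic carbon, such as an amine, a carboxylic acid or a longer chain ending in a hydroxyl, would carry the number beyond the scatter in either direction. They also leave open whether any exchange elsewhere on the shared core would move the number further than these three groups have done.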